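Swapping the indole amide for a cinnamamide on a long-chain threonine scaffold

The compounds below may be only part of what the source reports. "The series", "measured", "known", "first", "only" and "open" are said of these compounds alone.

Measured so far in a functional assay on A-431 cells (Homo sapiens) for cytotoxicity, read by MTT assay, with a stated time of 48 h; a higher number here means a weaker inhibitor, a lower number a stronger inhibitor:
- compound 1, `CCCCCCCCNC(=O)[C@@H](NC(=O)/C=C/c1ccccc1)[C@@H](C)O`: 36000 nM
- compound 2, `CCCCCCCCCCCCCCCCCCNC(=O)[C@@H](NC(=O)c1ccco1)[C@@H](C)O`: 19900 nM
- compound 3, `CCCCCCCCCCCCCCCCCCNC(=O)[C@@H](NC(=O)c1cc2ccccc2n1C)[C@@H](C)O`: 61000 nM

Compound 3 gives the highest number of the three in this assay, so it is the weakest inhibitor among them. Its gap to compound 2 is real, a 3.1-fold higher number from compound 2 to compound 3 (0.49 log units; beyond the scatter), while its gap to compound 1 stays within the scatter of repeated measurement, so compound 1 and compound 3 cannot be ranked against each other.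

The unmeasured compound 4, `CCCCCCCCCCCCCCCCCCNC(=O)[C@@H](NC(=O)/C=C/c1ccccc1)[C@@H](C)O`, differs from compound 3 in one place: 2-phenylethenyl in place of 1-methyl-1H-indol-2-yl on a carbonyl carbon. Among the compounds with values here, only one measured step bears directly on the amide-attached group, the change from compound 2 to compound 3, and it was modest. Compound 1 carries the same 2-phenylethenyl group as compound 4 but a shorter chain, and in this assay compound 1 gives 36000 nM, a number close to that of compound 3.

Taken together, a small downward move is expected, a 2.0-fold lower number from compound 3 to compound 4 (0.31 log units; beyond the scatter), likely within the scatter. Compound 4 is therefore estimated at 30000 nM, with a plausible range from 12000 nM to 80000 nM.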

Compound 4, half-maximal inhibitory concentration: 177000 nM
Estimate against measurement, compound 4: 5.9-fold (0.77 log units) below; measured number outside the range, above it.
By their numbers in this assay, from the lowest: compounds 2, 1 and 3 (each within the scatter of the next, the first and the last beyond it); then compound 4.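

In this assay, within the data shown here, the group on the carbonyl carbon proves to matter more than the single earlier step could show: 2-phenylethenyl in place of 1-methyl-1H-indol-2-yl gives a 2.9-fold higher number from compound 3 to compound 4 (0.46 log units; beyond the scatter) and 2-phenylethenyl in place of furan-2-yl gives an 8.9-fold higher number from compound 2 to compound 4 (0.95 log units; beyond the scatter) so compound 4 is the weakest inhibitor of the four. Among these compounds, the chain counts as well, which no earlier pair could reveal: with 2-phenylethenyl held fixed, decyl in place of hydrogen on the chain gives a 4.9-fold higher number from compound 1 to compound 4 (0.69 log units; beyond the scatter) so here the longer chain goes with weaker inhibition. Nothing measured on these compounds accounts for either change.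

Whether lengthening the chain has the same effect with furan-2-yl or 1-methyl-1H-indol-2-yl on the carbonyl carbon remains open, since the compounds shown compare the two chain lengths only with 2-phenylethenyl. Also open, on these data alone, are how a chain of intermediate length such as dodecyl would behave and whether a 2-phenylethyl group, which lacks the double bond outside the ring, would behave like 2-phenylethenyl.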